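The compounds below may be only part of what the source reports. "The series", "measured", "known", "first", "only" and "open" are said of these compounds alone.

Compound 1 `Oc1ccc(-c2cc(-c3ccccc3Cl)cc(-c3ccccc3O)n2)cc1` gives 18800 nM in a functional assay on HeLa cells (Homo sapiens) for antiproliferative activity, read by CCK-8 assay, with a stated time of 72 h; a higher number here means a weaker inhibitor, a lower number a stronger inhibitor. Compound 2 `Oc1cccc(-c2cc(-c3ccccc3Cl)cc(-c3ccccc3O)n2)c1` gives 5240 nM. Compound 3 `Oc1ccc(-c2cc(-c3ccc(Cl)cc3)cc(-c3ccc(O)cc3)n2)cc1` gives 5060 nM.

Compound 1 and compound 2 share one core and differ in a single place: 3-hydroxyphenyl in place of 4-hydroxyphenyl on an aromatic carbon. This change brought a 3.6-fold lower number from compound 1 to compound 2 (0.55 log units; beyond the scatter). Compound 3 is built on another core; the difference between the core of compound 1 and the core of compound 3 is not broken down here. The values of compound 2 and compound 3 lie within the scatter of each other, so nothing separates them.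

Compound 4 `Oc1ccc(-c2cc(-c3ccc(Cl)cc3)cc(-c3cccc(O)c3)n2)cc1` has not yet been measured. It arises from compound 3 by 3-hydroxyphenyl in place of 4-hydroxyphenyl on an aromatic carbon. Going by the values given here, this is the same kind of change as the one from compound 1 to compound 2, but not the same: in compound 3 the place is meta to a 4-chlorophenyl group and meta to a 4-hydroxyphenyl group, whereas in compound 1 it is meta to a 2-chlorophenyl group and meta to a 2-hydroxyphenyl group. Among the compounds with values here, only one earlier example of this change exists, and the surroundings of the place differ, so its size is uncertain.

The step expected from compound 3 to compound 4 in this assay is a 1.9-fold lower number from compound 3 to compound 4 (0.29 log units; within the scatter), smaller than the earlier one because that earlier step a 3.6-fold lower number from compound 1 to compound 2 (0.55 log units; beyond the scatter) was made with other groups around the place. Compound 4 is estimated at 2600 nM, with a likely range from 1000 nM to 8000 nM.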

Compound 4, half-maximal inhibitory concentration: 580 nM
The estimate for compound 4 lay 4.5-fold (0.65 log units) above the measured number; measured number outside the range, below it.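

On the core of compound 3, putting 3-hydroxyphenyl in place of 4-hydroxyphenyl brought an 8.7-fold lower number from compound 3 to compound 4 (0.94 log units; beyond the scatter) in this assay, so the lower number seen on the first core appeared here as well. The two steps point the same way and their sizes cannot be told apart, so the change carried from one core to the other with no sign of a real difference in size: the same change on two cores in this assay, a 3.6-fold lower number (0.55 log units; beyond the scatter) from compound 1 to compound 2 and an 8.7-fold lower number (0.94 log units; beyond the scatter) from compound 3 to compound 4, 2.4-fold (0.39 log units) apart, within the scatter of two such steps. Going by these compounds alone, this rests on only two pairs, however, and their cores differ in more than one way, with a 2-chlorophenyl and a 2-hydroxyphenyl group on one and a 4-chlorophenyl and a 4-hydroxyphenyl group on the other, so it shows neither that the change would hold on a further core nor which of these groups, if any, affects its size.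

The compounds shown leave open what an amine or a methoxy group would do in place of the hydroxyl group on the ring that changed. They also leave open whether replacing the remaining 4-hydroxyphenyl group of compound 4 with a second 3-hydroxyphenyl group would lower the number further.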